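The source may hold more compounds than are shown below. What is called first, only, known or untested is meant among the compounds shown, and "the series" means these compounds.

Measured so far:
compound 1 `Cn1nc(COc2cc(F)c(F)c(F)c2)c2c1CCN(C(=O)Nc1ccc(Cl)cc1)C2`, 3300 nM in an assay on cells for inhibition of Pendrin (Mus musculus), read by fluorescence, with a stated time of 10 min; on this read-out higher numbers stand for weaker inhibition and lower numbers for stronger inhibition
compound 2 `Cn1nc(COc2cc(F)cc(F)c2)c2c1CCN(C(=O)NC1CCCCC1)C2`, > 10000 nM

Compound 1 gives a numerical half-maximal inhibitory concentration of 3300 nM in this assay. On these data alone, compound 2 gives only a limit in this assay, > 10000 nM, so its true value is unknown beyond that; this is the limit of > 10000 nM in this assay, at which 1 of the 2 values shown sits. Compound 1 and compound 2 differ in two places at once, the aryl ether and the urea substituent, so what the gap between them shows cannot be assigned to either change.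

Compound 3 `Cn1nc(COc2cc(F)cc(F)c2)c2c1CCN(C(=S)NC1CCCCC1)C2` differs from compound 2 in one place: a group of 9 heavy atoms (7 carbon, 1 nitrogen, 1 sulfur; one six-membered non-aromatic ring of carbon only) in place of a group of 9 heavy atoms (7 carbon, 1 nitrogen, 1 oxygen; one six-membered non-aromatic ring of carbon only), on an amine nitrogen in a ring. Among the compounds with values here, no measured pair shows the effect of this exchange of a carbonyl oxygen for a sulfur on the urea, so the expected step rests only on the position of compound 2 at the limit. The expectation is a step of about none beyond the scatter, a step that the limit leaves unreadable from compound 2 to compound 3, with compound 3 most likely again reported only as a limit. The estimate for compound 3 in this assay is 15000 nM, in a range from 4000 nM to 50000 nM.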

Compound 3, half-maximal inhibitory concentration: > 10000 nM
Compound 3 ended at the assay's limit (the forecaster's own chance of this, stated with the estimate: 75%); the middle value does not contradict the limit.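

Compound 2 and compound 3 both end at a limit in this assay, so no step can be read for the exchange of the carbonyl oxygen for a sulfur: the limit of > 10000 nM in this assay, at which 2 of the 3 values shown sit.

Still open, on these data alone, are how the carbonyl and sulfur forms compare at a measurable strength and whether the aryl ether or the urea substituent separates compound 1 from compound 2.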